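A few compounds are considered here, and "the series" means these few. Any claim that something is new, unique, unknown or untested is made for them only; others in the source may bear on it.

Measured in an ADME assay on L6 cells (Rattus norvegicus) for cytotoxicity; on this read-out lower numbers stand for stronger inhibition and higher numbers for weaker inhibition:
- compound 1 `CN(C)C12CC(OC(=O)CCN3CCCC3)C(C(c3ccccc3)C1)C(c1ccccc1)C2`: 26000 nM
- compound 2 `O=C(CCN1CCCC1)OC1CC2(N3CCCC3)CC(c3ccccc3)C1C(c1ccccc1)C2`: 21900 nM
- compound 3 `O=C(CCN1CCCC1)OC1CC2(N3CCCCC3)CC(c3ccccc3)C1C(c1ccccc1)C2`: 12500 nM

Compound 3 stands at 12500 nM. For the measured compounds named here, one measured step is a 1.8-fold lower number from compound 2 to compound 3 (0.24 log units; within the scatter), while the only step past the scatter is the modest 2.1-fold lower number from compound 1 to compound 3 (0.32 log units; beyond the scatter).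

Compound 4 `O=C(CCN1CCC(O)CC1)OC1CC2(N3CCCCC3)CC(c3ccccc3)C1C(c1ccccc1)C2` is the next to consider. Its change from compound 3 is 4-hydroxypiperidin-1-yl in place of pyrrolidin-1-yl on a saturated chain carbon, two bonds along the chain from a carbonyl carbon, with 4-hydroxypiperidin-1-yl in place of pyrrolidin-1-yl on a saturated chain carbon, two bonds along the chain from a carbonyl carbon.

Going by the values given here, no measured step touches this chain, and none brings in the hydroxyl-bearing ring. The closest guide is a swap of the same two ring sizes on a saturated ring carbon, a 1.8-fold lower number from compound 2 to compound 3 (0.24 log units; within the scatter), and a 1.2-fold lower number from compound 1 to compound 2 (0.07 log units; within the scatter) is also small. With steps this small, no change beyond the scatter is expected in this assay, with only a slight lean towards a higher number. The expected step is a 1.4-fold higher number from compound 3 to compound 4 (0.16 log units; within the scatter). Compound 4 is estimated at 18000 nM, with an expected range of 7000 nM to 45000 nM.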

Compound 4, half-maximal inhibitory concentration: 28500 nM
Beside the measured number, compound 4's estimate is 1.6-fold (0.20 log units) below it; measured number inside the range.
By their numbers in this assay, from the lowest: compounds 3, 2, 1 and 4 (each within the scatter of the next, the first and the last beyond it).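

In this assay, the chain position turns out to be able to move the read-out: 4-hydroxypiperidin-1-yl in place of pyrrolidin-1-yl, on a saturated chain carbon, two bonds along the chain from a carbonyl carbon, gives a 2.3-fold higher number from compound 3 to compound 4 (0.36 log units; beyond the scatter) as the step. The earlier steps all changed the amine on a saturated ring carbon and ran towards lower numbers, so this is the first step shown at the chain position and the first towards a higher number. The step is modest, and no measurement shown bears on its cause.

The compounds shown leave open whether the six-membered ring or the hydroxyl accounts for the step, since both enter together; a plain piperidin-1-yl on this chain would separate them. Also open, from the compounds shown here alone, is how a morpholin-4-yl ring or a longer chain would read at this position.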